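The compounds below may be only part of what the source reports. "The series", "measured", "known", "first", "only" and "open" are said of these compounds alone.

Working notes on the series. In a functional assay on Jurkat cells (Homo sapiens) for antiproliferative activity, read by MTT assay, with a stated time of 48 h (on this read-out lower numbers stand for stronger inhibition and higher numbers for weaker inhibition), compound 1 (`O=C(CCCCCCn1cc(Nc2ncc(Cl)c(Nc3cccc(Cl)c3)n2)cn1)NO`) gives 100 nM, compound 2 (`CNc1nc(Nc2cnn(CCCCCCC(=O)NO)c2)ncc1Cl`) gives 70 nM and compound 3 (`O=C(CCCCCCn1cc(Nc2ncc(Cl)c(Nc3ccccc3)n2)cn1)NO`) gives 90 nM. Compound 3 therefore lies within the scatter of both other compounds, and the three values form a single band.

The next compound is compound 4 (`O=C(CCCCCCn1cc(Nc2ncc(Cl)c(NC3CC3)n2)cn1)NO`), which differs from compound 3 only at the anilino group. The change is cyclopropyl in place of phenyl on a nitrogen on an aromatic ring.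

Among the compounds with values here, two measured steps concern this same nitrogen. Replacing methyl with phenyl gives a 1.3-fold higher number from compound 2 to compound 3 (0.11 log units; within the scatter), and replacing 3-chlorophenyl with methyl gives a 1.4-fold lower number from compound 1 to compound 2 (0.15 log units; within the scatter). Removing the chloro from the phenyl group gives a 1.1-fold lower number from compound 1 to compound 3 (0.05 log units; within the scatter), which bears on the change less directly. Within the data shown here, all three steps are small, but no compound with cyclopropyl on this nitrogen has been measured, so the range is kept wide.

No step beyond the scatter is expected in this assay. The estimated change is a 1.1-fold lower number from compound 3 to compound 4 (0.05 log units; within the scatter). The expected value for compound 4 is 80 nM, with an estimated range of 35 nM to 200 nM.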

Compound 4, half-maximal inhibitory concentration: 50 nM
For compound 4 the middle estimate is 1.6-fold (0.20 log units) above the measured one, and the stated range covers the measured number.
By their numbers in this assay, from the lowest: compounds 4, 2, 3 and 1 (each within the scatter of the next).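

On the nitrogen on an aromatic ring, in this assay, cyclopropyl in place of phenyl gives a step that stays within the scatter (a 1.8-fold lower number from compound 3 to compound 4 (0.26 log units; within the scatter)), and the same holds for cyclopropyl in place of methyl (a 1.4-fold lower number from compound 2 to compound 4 (0.15 log units; within the scatter)) and for cyclopropyl in place of 3-chlorophenyl (a 2.0-fold lower number from compound 1 to compound 4 (0.30 log units; within the scatter)). The earlier compounds shown here carried only methyl, phenyl and 3-chlorophenyl at this position, so compound 4 extends the single band to a three-membered non-aromatic ring of carbon only, and across these four compounds this read-out does not separate an aromatic ring, a non-aromatic ring and a methyl on this nitrogen. No measurement is available that would explain this flat picture.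

The compounds shown leave open whether a morpholine ring, a carboxylic acid or a longer alkyl chain on this nitrogen would stay in the same band. They also leave open whether a plain amino group, with hydrogen in place of cyclopropyl, would do so, and whether the band would hold with a different group in place of the chloro on the shared core.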